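The source may hold more compounds than are shown below. What is called first, only, known or untested is meant among the compounds shown, and "the series" means these compounds.

Measured compounds:
compound 1 `Cc1c(OCCCCOCOc2ccc(C(=O)O)cc2)ccc(C(=O)CC2CCCC2)c1O`, 95.4%
compound 2 `Cc1c(OCCCCOc2ccc(C(=O)O)cc2Cl)ccc(C(=O)CC2CCCC2)c1O`, 82.2%
compound 3 `Cc1ccc(C(=O)O)cc1OCCCCOc1ccc(C(=O)CC2CCCC2)c(O)c1C`, 67.5%

In an assay on HEK293 cells for positive allosteric modulation of metabotropic glutamate receptor 2 (Rattus norvegicus), read by thallium flux, with a stated time of 2.5 min (a higher number here means a larger maximal response, a lower number a smaller maximal response), compound 3 gives the lowest of the three numbers, with compound 2 nearest at a number 14.7 percentage points lower from compound 2 to compound 3 (beyond the scatter) and compound 1 furthest at a number 27.9 percentage points lower from compound 1 to compound 3 (beyond the scatter). Compound 4 `Cc1cc(OCCCCOc2ccc(C(=O)CC3CCCC3)c(O)c2C)ccc1C(=O)O` differs from compound 3 only at the aromatic end of the chain: 4-carboxy-3-methylphenyl in place of 5-carboxy-2-methylphenyl on an oxygen on a saturated carbon. Within the data shown here, no measured step swaps these two groups directly; the steps that bear on it are the two exchanges of the same aryl group, a number 27.9 percentage points lower from compound 1 to compound 3 (beyond the scatter) and a number 14.7 percentage points lower from compound 2 to compound 3 (beyond the scatter), both modest and both lowering toward compound 3. Since the 4-carboxy-3-methylphenyl is a closer relative of the 4-carboxy-2-chlorophenyl of compound 2, a modest rise, a number 10.5 percentage points higher from compound 3 to compound 4 (beyond the scatter), is expected, with compound 4 estimated at 78% (range 62% to 92%).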

Compound 4, largest response reached (reported as percent of maximum), in percent of the reference or control that the assay uses: 83.6%
Estimate against measurement, compound 4: 5.6 percentage points below; the measured number falls inside the stated range.
By their numbers in this assay, from the lowest: compound 3; then compounds 2 and 4 (each within the scatter of the next); then compound 1.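

In this assay, the position of the carboxylic acid and methyl on the ring matters: with the same atoms, 4-carboxy-3-methylphenyl in place of 5-carboxy-2-methylphenyl gives a number 16.1 percentage points higher from compound 3 to compound 4 (beyond the scatter). Swapping in 4-carboxy-3-methylphenyl for 4-carboxy-2-chlorophenyl gives a number 1.4 percentage points higher from compound 2 to compound 4 (within the scatter), so these two groups cannot be told apart here, while replacing (4-carboxyphenoxy)methyl with it gives a number 11.8 percentage points lower from compound 1 to compound 4 (beyond the scatter). Nothing measured here accounts for the effect of moving these groups. Still open, on these data alone, is whether a fluorine in place of that methyl, or a tetrazole in place of the carboxylic acid, would keep this response.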